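Adding a methylsulfonyl group to the benzoyl ring of compound 1

The compounds below may be only part of what the source reports. "The series", "measured", "known", "first", "only" and "open" are said of these compounds alone.

Compound 1, with structure `O=C(c1ccccc1)N1CCC(N(C2CC2)S(=O)(=O)c2cccc(C(F)(F)F)c2)CC1`, carries a plain benzoyl group on a shared core that also bears a cyclopropyl-substituted sulfonamide. Its close relatives differ only in this benzoyl ring: compound 2, `O=C(c1cccc(OC(F)(F)F)c1)N1CCC(N(C2CC2)S(=O)(=O)c2cccc(C(F)(F)F)c2)CC1`, bears a trifluoromethoxy group, and compound 3, `O=C(c1ccccc1OC(F)(F)F)N1CCC(N(C2CC2)S(=O)(=O)c2cccc(C(F)(F)F)c2)CC1`, bears the same group at another position. In an assay on cells for inhibition of Voltage-dependent L-type calcium channel subunit alpha-1C (Homo sapiens), read by FLIPR and calcium flux, tested at 1 uM (a lower number here means a weaker effect, a higher number a stronger effect of the compound at the concentration tested), compound 2 gives 60%, whereas compound 1 gives "not determined" (no result reported) and compound 3 gives "not determined" (no result reported). Going by these compounds, compound 1 therefore stands nowhere on the numbers at hand; its own activity is unknown, and nothing shows how a change on this ring shifts the read-out.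

Compound 4, `CS(=O)(=O)c1ccccc1C(=O)N1CCC(N(C2CC2)S(=O)(=O)c2cccc(C(F)(F)F)c2)CC1`, arises from compound 1 by the change (methylsulfonyl in place of hydrogen on an aromatic carbon), placing the new group on an aromatic carbon of the six-membered ring, ortho to a large group. Going by the values given here, no measured step exists to size this change, so its direction in this assay cannot be drawn from the data. Going only by the single number of compound 2, the inhibition of compound 4 is expected to be around 40%, estimated to lie between 10% and 70%.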

Compound 4, a percentage reported as inhibition, at one concentration (the size of the read-out at that concentration, not a potency): 19%
Beside the measured number, compound 4's estimate is 21 percentage points above it; the range from low to high includes it.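

In this assay, going by these compounds alone, exchanging the substituted benzoyl ring gives a number 41 percentage points lower from compound 2 to compound 4 (beyond the scatter), the first sign that a change on this ring can move the read-out beyond the scatter. The step swaps both the group and its place on the ring, so it cannot credit the change to methylsulfonyl alone. No measurement shown here accounts for the difference.

Compound 1 and compound 3 have no value, so the steps from them to compound 4 cannot be read, and the change from hydrogen to methylsulfonyl remains unsized. Also open, going by these compounds, is how the read-out would respond to an amine or a carboxylic acid in place of methylsulfonyl on the same aromatic carbon.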